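This account rests on a few compounds, and the source may have more. Where it says the series, first, only, none or still open, it means among the compounds named here.

Measured so far:
compound 1 `CCn1cc(-c2nc3ccccc3[nH]2)c(=O)c2cc(F)c(N3CCNCC3)nc21` gives 4900 nM
compound 2 `CCn1cc(-c2nc3ccc([N+](=O)[O-])cc3o2)c(=O)c2cc(F)c(N3CCNC(C)C3)c(F)c21` gives 800 nM

In a functional assay on A549 cells (Homo sapiens) for cytotoxicity, read by sulforhodamine B assay, with a stated time of 48 h (on this read-out lower numbers stand for stronger inhibition of growth and higher numbers for weaker inhibition of growth), compound 1 stands highest of the two numbers at 4900 nM and compound 2 lies lower at 800 nM with a gap beyond the scatter.

Compound 3 `CCn1cc(-c2nc3ccc(N)cc3[nH]2)c(=O)c2cc(F)c(N3CCNCC3)nc21` is still unmeasured. It keeps the core of compound 1 and carries one change: amino in place of hydrogen on an aromatic carbon. Among the compounds with values here, no pair of measured compounds isolates this change, so no measured step sets its size. Compound 2 at 800 nM differs from compound 1 in several places and offers only a weak hint toward a lower number.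

The expectation in this assay is therefore a small move in that direction, not beyond the scatter. The estimated step is a 1.6-fold lower number from compound 1 to compound 3 (0.21 log units; within the scatter) and a result with no real change would be no surprise. For compound 3 the estimate is 3000 nM within an expected range of 900 nM to 9000 nM for this measurement.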

Compound 3, concentration for 50% growth inhibition: 500 nM
Compound 3: middle estimate off by 6.0-fold (0.78 log units), on the high side, and the stated range ends above it.
By their numbers in this assay, from the lowest: compounds 3 and 2 (each within the scatter of the next); then compound 1.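

In this assay the exchange of hydrogen for amino on this aromatic carbon of the six-membered aromatic ring of carbon only brings a 9.8-fold lower number from compound 1 to compound 3 (0.99 log units; beyond the scatter) and gives the series its first change isolated in one place. This carbon of the core of compound 1 therefore tolerates a substituent, and growth inhibition in these cells responds to a single amino group placed there, with no other part of the structure altered. Nothing measured here explains the size of this step.

Open, going by these compounds, is whether the step is specific to the amino group or would also appear with another small group on the same carbon, such as a hydroxyl, a methoxy, a dimethylamino or an acetamide group on the same core. Also open is whether the same exchange would give a step of similar size on a different core, since the one step shown rests on a single pair of compounds and cannot be taken as a trend for the series.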